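Formyl in place of hydroxymethyl: cytotoxicity expected to stay beyond the limit

A few compounds are considered here, and "the series" means these few. Any claim that something is new, unique, unknown or untested is made for them only; others in the source may bear on it.

The shared core is shown by compound 1 `C=C1C(=O)[C@H]2C[C@@H]1CC1=C2[C@]2(C)CCC[C@](C)(CO)[C@H]2CC1`. In a functional assay on LNCaP cells (Homo sapiens) for cytotoxicity, read by MTT assay, with a stated time of 24 h (a higher number here means a weaker inhibitor, a lower number a stronger inhibitor), compound 1 reaches only a limit of the assay, > 50000 nM. Compound 2 `C[C@@H]1C(=O)[C@H]2C[C@]1(O)CC1=C2[C@]2(C)CCC[C@](C)(CO)[C@H]2CC1` carries a methyl group and a hydroxy group that the shared core lacks; in this assay compound 2 likewise gives only a limit, > 50000 nM. Compound 3 `C[C@@H]1C(=O)[C@H]2C[C@]1(O)CC1=C2[C@]2(C)CCCC(C)(C)[C@H]2CC1`, in which hydrogen stands in place of hydroxy on a saturated chain carbon bound to a saturated ring carbon, also gives only a limit in this assay, > 50000 nM. The step that the two limits leave unreadable from compound 2 to compound 3 therefore cannot be read in size or direction, and the whole of what the measured steps offer is the limit of > 50000 nM in this assay, at which 3 of the 3 values shown sit.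

Compound 4 `C[C@@H]1C(=O)[C@H]2C[C@]1(O)CC1=C2[C@]2(C)CCC[C@](C)(C=O)[C@H]2CC1` differs from compound 2 by formyl in place of hydroxymethyl on a saturated ring carbon. Going by the values given here, no measured pair touches the hydroxymethyl group, so the three limits are all the evidence that bears on this step. Since every measured compound sits at the same limit, a readable change is not expected, and the step from compound 2 to compound 4 is expected to be a step that the limit leaves unreadable from compound 2 to compound 4, within the scatter. Compound 4 is estimated at 60000 nM, with a range from 20000 nM to 200000 nM, and most probably is itself reported only as a limit in this assay.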

Compound 4, half-maximal inhibitory concentration: > 50000 nM
Compound 4: a limit, no number (the forecaster's own chance of this, stated with the estimate: 80%); the middle value does not contradict the limit.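

Compound 4, like compound 2, gives only a limit in this assay, so no step can be read from the exchange of hydroxymethyl for formyl, in size or in direction: the limit of > 50000 nM in this assay, at which 4 of the 4 values shown sit.

The compounds shown leave open what any of these structural differences does to cytotoxicity in this assay, and which structure, if any, would give a number there.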